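Aryl variation on a fused-core piperazine series

The compounds below may be only part of what the source reports. "The series", "measured", "known", "first", "only" and "open" are said of these compounds alone.

Measured so far in an assay on cells for displacement of a labelled ligand from adenosine receptor A3 (Homo sapiens), read by scintillation counting and radioligand binding, with a stated time of 180 min, tested at 10 uM; on this read-out lower numbers stand for less inhibition and higher numbers for more inhibition at the one concentration tested (going by the name of the read-out):
compound 1 `CN1CCN(c2nc(-c3cccc(O)c3)nc3c2ncn3C)CC1` gives 63.8%
compound 2 `CN1CCN(c2nc(-c3cccc(Cl)c3)nc3[nH]cnc23)CC1` gives a limit of > 80%
compound 3 `CN1CCN(c2nc(-c3cc(Cl)ccc3Cl)nc3[nH]cnc23)CC1` gives a limit of > 80%

Compound 3 stands at the upper limit of this assay; its value is a limit, not a number. The same is true of compound 2, so the step that the two limits leave unreadable from compound 2 to compound 3 cannot be read, because of the limit of > 80% in this assay, at which 2 of the 3 values shown sit. Going by the values given here, compound 1 carries a methyl on the core that compounds 2 and 3 lack, and no single-place step links it to either of them; its value is simply the one numeric read-out in the set.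

Compound 4 `CN1CCN(c2nc(-c3cccc(O)c3)nc3[nH]cnc23)CC1` is to be measured in this assay. It differs from compound 3 in one place: 3-hydroxyphenyl in place of 2,5-dichlorophenyl on an aromatic carbon. Among the compounds with values here, no measured step bears directly on this change, since the only step of the set is unreadable. The estimate for compound 4 therefore rests loosely on the fact that compound 1, the other 3-hydroxyphenyl member, gives 63.8%. The chlorinated members, compound 2 and compound 3, are each reported only as a limit of this assay. Compound 4 is expected to give 68% (range 45% to 85%), an expected step of a number at least 12 percentage points lower from compound 3 to compound 4 (beyond the scatter) from compound 3, with a real chance that it is reported only as a limit.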

Compound 4, a percentage reported as inhibition, at one concentration (the size of the read-out at that concentration, not a potency): > 80%
Compound 4: a limit, no number; the forecaster's own chance of this, stated with the estimate: 30%; at least 12 percentage points between middle value and limit.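

In this assay, going by these compounds alone, hydrogen in place of methyl on an aromatic nitrogen, with the 3-hydroxyphenyl group kept, is a number at least 16.2 percentage points higher from compound 1 to compound 4 (beyond the scatter), the first step that can be read in size, and it places the change on the core rather than on the aryl group. Compound 4 gives > 80%, which is a limit of the assay and not a number. The steps to compound 4 from compound 2 and from compound 3 cannot be read, so 3-hydroxyphenyl and the chlorinated aryl groups on the aromatic carbon between two ring nitrogen atoms remain unseparated, and the cause lies in the read-out: the limit of > 80% in this assay, at which 3 of the 4 values shown sit.

Any order among compound 2, compound 3 and compound 4 remains open until a read-out gives numbers for all three, and so does whether the step seen on the nitrogen holds with a chlorinated aryl group. Also open, from the compounds shown here alone, is how a carboxylic acid or an amine on the phenyl ring, in place of hydroxy or chloro, would read in this assay.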